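Moving the Methyl Group on the Anilino Ring

The source may hold more compounds than are shown below. What is called first, only, known or untested is meant among the compounds shown, and "the series" means these compounds.

Compound 1 `COc1ccc(Nc2nc(SCc3cn(Cc4ccccc4Cl)nn3)nc(-c3ccccc3)c2C#N)cc1`: 7560 nM
Compound 2 `Cc1ccccc1Nc1nc(SCc2cn(Cc3ccccc3Cl)nn2)nc(-c2ccccc2)c1C#N`: 7280 nM

In a functional assay on MGC-803 cells (Homo sapiens) for inhibition, read by MTT assay, with a stated time of 72 h (on this read-out higher numbers stand for weaker inhibition and lower numbers for stronger inhibition), compound 1 gives 7560 nM and compound 2 gives 7280 nM. The step of a 1.0-fold lower number from compound 1 to compound 2 (0.02 log units; within the scatter) shows that swapping 4-methoxyphenyl for 2-methylphenyl on the nitrogen on the aromatic ring leaves the inhibition unchanged. Compound 2 stands at the lower of the two numbers, but its gap to compound 1 is within the scatter, so no order between them can be read.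

Compound 3 `Cc1ccc(Nc2nc(SCc3cn(Cc4ccccc4Cl)nn3)nc(-c3ccccc3)c2C#N)cc1` differs from compound 2 by 4-methylphenyl in place of 2-methylphenyl on a nitrogen on an aromatic ring. Within the data shown here, the only measured step that bears on it, a 1.0-fold lower number from compound 1 to compound 2 (0.02 log units; within the scatter), was flat, and no pair compares the two methylphenyl groups directly. Compound 3 is therefore expected to show no step beyond the scatter in this assay, a 1.0-fold lower number from compound 2 to compound 3 (0.00 log units; within the scatter). The estimate for compound 3 is 7200 nM, with a range from 3000 nM to 17000 nM.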

Compound 3, half-maximal inhibitory concentration: 7190 nM
Estimate against measurement, compound 3: 1.0-fold (0.00 log units) above, and the stated range covers the measured number.
By their numbers in this assay, from the lowest: compounds 3, 2 and 1 (each within the scatter of the next).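

In this assay, the change from 2-methylphenyl to 4-methylphenyl on the nitrogen is a 1.0-fold lower number from compound 2 to compound 3 (0.01 log units; within the scatter) and so gives no readable difference between these two placements of the methyl group. Methyl in place of methoxy on an aromatic carbon is a 1.1-fold lower number from compound 1 to compound 3 (0.02 log units; within the scatter) and is just as flat, so all three compounds now sit within the scatter of one another, and neither the kind of small group nor the placement of the methyl separates them. No supporting data are available to explain this flatness.

The compounds shown leave open whether a carboxylic acid, an amine or a fluorine on this phenyl ring would produce a step beyond the scatter. They also leave open whether a cyclohexyl group in place of the phenyl ring on the nitrogen would do so.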